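The source may report more compounds than this note shows. Statements on the series, on what has been measured and on what is new or still open speak of the compounds shown alone.

Measured so far in an assay on microsomes from brain for inhibition of Fatty-acid amide hydrolase 1 (Rattus norvegicus), read by fluorescence and HPLC, with a stated time of 60 min; on this read-out higher numbers stand for weaker inhibition and lower numbers for stronger inhibition:
- compound 1, `CC(Oc1ccc(-c2ccccc2)cc1)C(=O)Cn1nnc(-c2ccc(Cl)cc2)n1`, 25 nM
- compound 2, `COC(=O)c1ccc(-c2nnn(CC(=O)C(C)Oc3ccc(Oc4ccc(Cl)cc4)cc3)n2)cc1`, 47 nM
- compound 3, `COC(=O)c1ccc(-c2nnn(CC(=O)C(C)Oc3ccc(Oc4ccc(C(F)(F)F)cc4)cc3)n2)cc1`, 130 nM

Compound 3 sits at the top of the three numbers in this assay: compound 2 is the nearest, with a lower number, and compound 1 the furthest. For the measured compounds named here, the only step between compounds that differ in one place is a 2.8-fold higher number from compound 2 to compound 3 (0.44 log units; beyond the scatter), a modest change and the sole measured move across the outer aromatic ring.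

Compound 4, `COC(=O)c1ccc(-c2nnn(CC(=O)C(C)Oc3ccc(-c4ccccc4)cc3)n2)cc1`, is to be measured in this assay. It differs from compound 3 by phenyl in place of 4-(trifluoromethyl)phenoxy on an aromatic carbon. Going by the values given here, no measured step covers this exact swap. Among the compounds with values here, compound 1 carries the same phenyl on the same part of the molecule but a chloro rather than a methyl ester on the aryl of the shared core, so no step to it is counted; compound 1 gives a number close to that of compound 2, and the two are within scatter of each other. That reading, together with the direction of the step from compound 2 to compound 3, points to compound 4 landing below compound 3, roughly where compound 2 sits.

The expected step is a 2.9-fold lower number from compound 3 to compound 4 (0.46 log units; beyond the scatter). Compound 4 is therefore estimated at 45 nM, in the range 15 nM to 140 nM.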

Compound 4, half-maximal inhibitory concentration in the Fatty-acid amide hydrolase 1 assay: 23 nM
The estimate for compound 4 lay 2.0-fold (0.29 log units) above the measured number; low and high end bracket the measured number.
By their numbers in the Fatty-acid amide hydrolase 1 assay, from the lowest: compounds 4, 1 and 2 (each within the scatter of the next, the first and the last beyond it); then compound 3.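

Phenyl on this aromatic carbon, para to a large group, does better in the Fatty-acid amide hydrolase 1 assay than either phenoxy group on the methyl ester core: the swap gives a 5.7-fold lower number from compound 3 to compound 4 (0.75 log units; beyond the scatter) and a 2.0-fold lower number from compound 2 to compound 4 (0.31 log units; beyond the scatter), so neither larger group is needed for inhibition in this pair of comparisons. With phenyl held fixed, the other end of the molecule makes no readable difference, as methoxycarbonyl and chloro on the shared core give a 1.1-fold lower number from compound 1 to compound 4 (0.04 log units; within the scatter), which shows that the ester is tolerated there alongside phenyl. In a physicochemical assay for lipophilicity, read by HPLC, tested at 5 mM (a lower number here means a more polar compound, a higher number a more lipophilic compound), compound 3 gives 6.2 and compound 4 gives 5.4. The swap from compound 3 to compound 4 also lowers lipophilicity, so the stronger inhibition of compound 4 may go with that drop, though it also goes with the smaller group: the measured partition coefficient of compound 3, 6.2, and of compound 4, 5.4, a number 0.80 log units lower (beyond the scatter)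

This single pair cannot separate lipophilicity from size, and a saturated cyclohexyl in place of phenyl would bear on that question. From the compounds shown here alone, it also remains open whether a carboxylic acid in place of methoxycarbonyl would be tolerated on the shared core as chloro and the ester are.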